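This account rests on a few compounds, and the source may have more. Where it says the series, first, only, none or still open, it means among the compounds named here.

Measured so far in this study:
- compound 1, `CCCCCC#Cc1cc2cn(COCCO)c(=O)nc2o1`: >= 100000 nM
- compound 2, `CCCCCc1cc2cn(COCCO)c(=O)nc2o1`: > 400000 nM
- compound 3, `CCCCCCCCCC#Cc1cc2cn(COCCO)c(=O)nc2o1`: >= 20000 nM

All three were tested in a functional assay on HEL cells (Homo sapiens), read by microscopy; on this read-out higher numbers stand for lower toxicity in this test and lower numbers for higher toxicity in this test. The value of compound 1 is a limit of the assay, not a number. The value of compound 2 is likewise a limit. The value of compound 3 is also a limit, so compound 3 stands at a limit only, and the two further values shown are limits too, as the limit of > 400000 nM in this assay, at which 1 of the 3 values shown sits, the limit of >= 100000 nM in this assay, at which 1 of the 3 values shown sits, and the limit of >= 20000 nM in this assay, at which 1 of the 3 values shown sits, record; its place among them cannot be read.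

The unmeasured compound 4, `CCCCC#Cc1cc2cn(COCCO)c(=O)nc2o1`, differs from compound 3 by hydrogen in place of pentyl on a saturated chain carbon, four bonds along the chain from a triple-bonded carbon. The two measured steps, a step that the two limits leave unreadable from compound 1 to compound 2 and a step that the two limits leave unreadable from compound 1 to compound 3, are both unreadable, so neither gives a size or a direction to lean on. Since every value shown sits at a limit, the result for compound 4 is expected to be another limit, with the step that the limit leaves unreadable from compound 3 to compound 4 estimated as essentially none. Compound 4 is therefore estimated at 100000 nM, in the range 20000 nM to 400000 nM.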

Compound 4, minimum cytotoxic concentration: > 100000 nM
Compound 4: a limit, no number; the forecaster's own chance of this, stated with the estimate: 80%; the middle value lies on the limit itself.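

In this assay compound 4 gives > 100000 nM as a limit of the assay and not a number. No step can be read between compound 4 and compound 1, compound 2 or compound 3, whose values are limits too. The compounds shown leave open whether changing the chain alters toxicity in this test at all.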